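This account rests on a few compounds, and the source may have more. Where it says the series, first, only, none or still open, it means among the compounds named here.

For the measured compounds named here, in an ADME assay on Caco-2 cells (Homo sapiens) for permeability, read by LC-MS, in the apical to basolateral direction, with a stated time of 60 min, at pH 6.5 (a lower number here means that the compound crosses the layer more slowly, a higher number that the compound crosses the layer faster), three related compounds have numbers so far. Compound 1 (`CC(C)(C)[C@@H](O)C(=O)N1C[C@@H]2C[C@@H]2[C@H]1C(=O)NCc1cc(Cl)ccc1-n1cnnn1`) gives 17 10^-6 cm/s and sits second highest of the three. Compound 3 (`O=C(NCc1cc(Cl)ccc1-n1cnnn1)[C@@H]1C[C@H]2C[C@H]2N1C(=O)[C@H](O)CC1CC1`) gives 6.9 10^-6 cm/s on the low side, while compound 2 (`O=C(O[C@@H](C(=O)N1N=CC[C@H]1C(=O)NCc1cc(Cl)ccc1-n1cnnn1)c1ccc(F)cc1)c1ccccc1`) gives 43 10^-6 cm/s on the high side. Both gaps to compound 1 lie beyond the usual scatter of repeat measurements. These three differ from each other in more than one place, so no single change can be read from them.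

Compound 4 (`O=C(NCc1cc(Cl)ccc1-n1cnnn1)[C@@H]1[C@H]2C[C@H]2CN1C(=O)[C@H](O)c1ccccc1`) has not yet been measured. Its difference from compound 1 is a single one (phenyl in place of tert-butyl on a saturated chain carbon bound to a carbonyl carbon and an oxygen on a saturated carbon), with phenyl in place of tert-butyl on a saturated chain carbon bound to a carbonyl carbon and an oxygen on a saturated carbon. Going by the values given here, no measured pair shows this swap, so the expectation is loose: a small drop that may not clear the scatter. The expected step is a 1.5-fold lower number from compound 1 to compound 4 (0.19 log units; within the scatter) by this estimate. For compound 4 the estimated value is 11 10^-6 cm/s with an expected range from 4 10^-6 cm/s to 30 10^-6 cm/s in this assay.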

Compound 4, apparent permeability: 12 10^-6 cm/s
For compound 4 the middle estimate is 1.1-fold (0.04 log units) below the measured one, and the stated range covers the measured number.
By their numbers in this assay, from the lowest: compounds 3, 4 and 1 (each within the scatter of the next, the first and the last beyond it); then compound 2.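

In this assay, phenyl in place of tert-butyl on a saturated chain carbon bound to a carbonyl carbon and an oxygen on a saturated carbon gives a 1.4-fold lower number from compound 1 to compound 4 (0.15 log units; within the scatter). For the compounds shown here, this is the first pair that differs in one place, and it shows that, on this core, the read-out does not separate these two groups at this position. Nothing available bears on the reason for this result.

The compounds shown leave open whether a group of a different kind at this carbon, such as an amine, a carboxylic acid or a longer chain, would give a step beyond the scatter. They also leave open whether phenyl in place of tert-butyl would give a similar result on the other cores in the series.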